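The source may report more compounds than this note shows. Statements on the series, on what has been measured and on what is new or still open speak of the compounds shown alone.

Measured compounds in a physicochemical assay for lipophilicity, read by HPLC, measured as chromatographic lipophilicity, at pH 7.4; on this read-out higher numbers stand for higher lipophilicity and lower numbers for lower lipophilicity:
compound 1 `CC[C@H]1OC(=O)[C@H](C)[C@@H](O[C@H]2C[C@@](C)(OC)[C@@H](OCCCNC(C)=O)[C@H](C)O2)[C@H](C)[C@@H](O[C@@H]2O[C@H](C)C[C@H](N(C)C)[C@H]2O)[C@](C)(O)C[C@@H](C)CN(C)[C@H](C)[C@@H](O)[C@]1(C)O` gives 2.06
compound 2 `CCCCCCCC(=O)NCCCO[C@H]1[C@H](C)O[C@@H](O[C@H]2[C@H](C)[C@@H](O[C@@H]3O[C@H](C)C[C@H](N(C)C)[C@H]3O)[C@](C)(O)C[C@@H](C)CN(C)[C@H](C)[C@@H](O)[C@](C)(O)[C@@H](CC)OC(=O)[C@@H]2C)C[C@@]1(C)OC` gives 4.1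

Among the measured compounds shown here, compound 2 holds the higher of the two numbers in this assay; the only other number, compound 1, lies lower, as a number 2.04 log units higher from compound 1 to compound 2 (beyond the scatter) shows. The unmeasured compound 3 `CC[C@H]1OC(=O)[C@H](C)[C@@H](O[C@H]2C[C@@](C)(OC)[C@@H](OCCCNC(=O)c3c(C)nn(C)c3Cl)[C@H](C)O2)[C@H](C)[C@@H](O[C@@H]2O[C@H](C)C[C@H](N(C)C)[C@H]2O)[C@](C)(O)C[C@@H](C)CN(C)[C@H](C)[C@@H](O)[C@]1(C)O` is reached from compound 2 by 5-chloro-1,3-dimethyl-1H-pyrazol-4-yl in place of heptyl on a carbonyl carbon whose other neighbour is an amide-type nitrogen. For the measured compounds named here, the single measured step bears on this only in part: it shows how much the saturated chain on the carbonyl carbon adds, hexyl in place of hydrogen, and no measured step brings in a ring with two hetero atoms and a chlorine at this place. Removing most of that chain while adding a small aromatic ring is therefore expected to take back part of what the chain gave, so a moderate fall of a number 1.10 log units lower from compound 2 to compound 3 (beyond the scatter) is expected. Compound 3 is estimated at 3, within 2.4 to 3.6.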

Compound 3, distribution coefficient: 2.52
For compound 3 the middle estimate is 0.48 log units above the measured one, and the stated range covers the measured number.
By their numbers in this assay, from the lowest: compound 1; then compound 3; then compound 2.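

In this assay, 5-chloro-1,3-dimethyl-1H-pyrazol-4-yl in place of heptyl on the carbonyl carbon gives a number 1.58 log units lower from compound 2 to compound 3 (beyond the scatter) and so does not keep the number reached with the long chain. Among the compounds shown here, the same ring in place of methyl at this carbon still gives a number 0.46 log units higher from compound 1 to compound 3 (beyond the scatter) and puts compound 3 much closer to compound 1 than to compound 2, the first reading at this position for an aromatic ring rather than a saturated chain. No measurement on hand accounts for either step.

The compounds shown do not separate what the ring itself contributes from what its chlorine and methyl groups contribute, since only one ring occurs at this carbon. An unsubstituted pyrazole, a phenyl ring or a propyl chain at the same carbonyl carbon would bear on this.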